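The compounds below may be only part of what the source reports. "The series", "measured", "known", "first", "only" and "open" are said of these compounds alone.

In a physicochemical assay for permeability, using PAMPA (a lower number here means that the compound crosses the layer more slowly, a higher number that the compound crosses the layer faster), compound 1 `COCCOc1cc2oc(=O)n(CCC(=O)O)c2cc1Cl` gives < 3 nm/s, which is a limit and not a number. Compound 3 `C[C@@H](Oc1cc2oc(=O)n(CCC(=O)O)c2cc1Cl)c1cccnn1` gives < 3 nm/s, again a limit. Compound 2 `O=C(O)CCn1c(=O)oc2cc(OCc3ccccc3)c(Cl)cc21` reads "not determined" (no result reported), so it offers no starting number in this assay. The next compound is compound 4 `C[C@@H](Oc1cc2oc(=O)n(CCC(=O)O)c2cc1Cl)c1ncco1`, and the change leading to it is a group of 7 heavy atoms (5 carbon, 1 nitrogen, 1 oxygen; one five-membered aromatic ring with 2 hetero atoms) in place of a group of 7 heavy atoms (7 carbon; one six-membered aromatic ring of carbon only), on an oxygen on an aromatic ring. The entering group also carries a defined stereocentre.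

Within the data shown here, the only measured step at this place on the series, a step that the two limits leave unreadable from compound 1 to compound 3, has no readable size, so it gives no measure for this change. What the series does show is the limit of < 3 nm/s in this assay, at which 2 of the 3 values shown sit. With no value for compound 2, no size or direction of step can be expected in this assay. Compound 3 gives < 3 nm/s with a six-membered aromatic ring with 2 hetero atoms in its group, and that limit is the closest guide to what is expected of compound 4. The estimate for compound 4 is 2 nm/s, with an expected range from 1 nm/s to 5 nm/s.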

Compound 4, apparent permeability: < 3 nm/s
Compound 4: only a limit was reported (the forecaster's own chance of this, stated with the estimate: 85%); the middle value is on the limit's open side.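

In this assay compound 4 gives < 3 nm/s, a limit and not a number. No new step can be read between compound 4 and compound 1 or compound 3, whose values are also limits. The compounds shown leave open how these three compare and where compound 2 stands.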